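This account rests on a few compounds, and the source may have more. Where it says the series, first, only, none or still open, it means among the compounds named here.

In a functional assay on the whole organism (arterial blood) with Rattus norvegicus as the target (on this read-out lower numbers stand for an effect already at smaller amounts and higher numbers for an effect only at larger amounts of compound), compound 2 `Cc1nc2cnccc2n1CC1CCN(C(=O)CCc2ccccc2)CC1` gives no number, only a limit of > 5 mg/kg. Compound 2 thus sits at the limit of > 5 mg/kg in this assay, at which 1 of the 3 values shown sits. Compound 1 `COC(=O)NC(CC(=O)N1CCC(Cn2c(C)nc3cnccc32)CC1)c1ccccc1` gives 0.035 mg/kg, and compound 3 `COc1ccccc1CCC(=O)N1CCC(Cn2c(C)nc3cnccc32)CC1` gives 0.045 mg/kg.

Compound 4 `Cc1nc2cnccc2n1CC1CCN(C(=O)N[C@@H](C)c2ccccc2)CC1` differs from compound 2 at one place: (1-phenylethyl)amino in place of phenethyl on a carbonyl carbon. Among the measured compounds shown here, no measured step makes this exact change. For the measured compounds named here, two measured steps bear on it indirectly, and both are large. One is an at least 140-fold higher number from compound 1 to compound 2 (2.15 log units; beyond the scatter), with hydrogen in place of (methoxycarbonyl)amino. The other is an at least 110-fold lower number from compound 2 to compound 3 (2.04 log units; beyond the scatter), with methoxy in place of hydrogen on an aromatic carbon. Each shows that a single change can separate compound 2 widely from a compound with a far lower number. A large step towards a lower number is therefore expected in this assay, though smaller than these two, and another limit remains possible. The expected change is an at least 10-fold lower number from compound 2 to compound 4 (1.00 log units; beyond the scatter). The estimate for compound 4 is 0.5 mg/kg, with an expected range of 0.05 mg/kg to 5 mg/kg.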

Compound 4, dose for 50% inhibition: 0.21 mg/kg
Beside the measured number, compound 4's estimate is 2.4-fold (0.38 log units) above it; measured number inside the range.
By their numbers in this assay, from the lowest: compounds 1 and 3 (each within the scatter of the next); then compound 4. At a limit, above all of these: compound 2.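

The earlier steps shown here changed only a substituent on the phenethyl of compound 2, whereas here the phenethyl itself gives way, and in this assay that replacement yields an at least 23-fold lower number from compound 2 to compound 4 (1.37 log units; beyond the scatter). A lower number at this place, on the carbonyl carbon bound to the amide-type nitrogen in a ring, therefore does not depend on keeping phenethyl with a methoxy or a (methoxycarbonyl)amino. (1-phenylethyl)amino, with its hydrogen-bond donor and defined stereocentre, reaches one as well. From the compounds shown here alone, the true size of this step stays unknown, as compound 2 stands only at a limit of the assay: the limit of > 5 mg/kg in this assay, at which 1 of the 4 values shown sits.

The compounds shown leave open which part of (1-phenylethyl)amino carries the step, the amino nitrogen or the branching methyl, and how the mirror-image stereocentre would read. Going by these compounds, it is also open how a longer chain or a carboxylic acid would read at this carbonyl carbon.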